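The compounds below may be only part of what the source reports. "The series", "measured", "known", "first", "only" and "open" are said of these compounds alone.

Working notes on an ADME assay on microsomes from liver (Homo sapiens) for pharmacokinetics; a lower number here means slower removal, a higher number faster removal of the compound. Compound 2 (`C[C@@H]1CN(c2nc(-c3cnn(C)c3)ncc2C#N)CCN1C(=O)C1(C)CC1`) gives < 16 mL/min/kg, which is a limit and not a number. Compound 1 (`C[C@@H]1C[C@H]1C(=O)N1CCN(c2nc(-c3cnn(C)c3)ncc2C#N)C[C@H]1C`) gives < 16 mL/min/kg, also a limit. Within the data shown here, the one measured step bearing on this position is a step that the two limits leave unreadable from compound 1 to compound 2, so it offers no size to carry over. Compound 4 (`C[C@@H]1CN(c2nc(-c3cnn(C)c3)ncc2C#N)CCN1C(=O)C1CC1`) differs from compound 2 by hydrogen in place of methyl on a saturated ring carbon. Compound 3 (`C[C@@H]1CN(c2nc(-c3cnn(C)c3)cnc2C#N)CCN1C(=O)C1CC1`) carries the same cyclopropylcarbonyl on a different core and gives 50 mL/min/kg, so it is no direct measure of this change. The expected result is a number no lower from compound 2 to compound 4 (the limit leaves the size open), with no move beyond the scatter foreseen, though the limit leaves any direction open. For compound 4 the estimate is 16 mL/min/kg, in an expected range of 8 mL/min/kg to 32 mL/min/kg.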

Compound 4, clearance: 21 mL/min/kg
Beside the measured number, compound 4's estimate is 1.3-fold (0.12 log units) below it; low and high end bracket the measured number.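

In this assay, compound 4 gives 21 mL/min/kg, the only exact number shown on this shared core. Hydrogen in place of methyl on the three-membered ring reads as an at least 1.3-fold higher number from compound 2 to compound 4 (0.11 log units; that floor lies within the scatter), and the 2-methylcyclopropyl comparison reads as an at least 1.3-fold higher number from compound 1 to compound 4 (0.11 log units; that floor lies within the scatter). Neither floor shows a move beyond the scatter, and the full size of each step stays unreadable because compound 1 and compound 2 each rest on a limit: the limit of < 16 mL/min/kg in this assay, at which 2 of the 4 values shown sit.

The step from compound 1 to compound 2 cannot be read. As far as these compounds go, how a fluorine or a hydroxymethyl on that ring would read in this assay remains open.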